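A few compounds are considered here, and "the series" means these few. Any claim that something is new, unique, unknown or untested is made for them only; others in the source may bear on it.

Working notes on the series in an ADME assay on microsomes from liver (Mus musculus, strain CD1) for metabolic stability, read by LC-MS, using NADPH, with a stated time of 60 min; on this read-out higher numbers stand for a longer-lived compound and lower numbers for a shorter-lived compound. Compound 1 `N=c1c2c(-c3ccccc3)c(-c3ccccc3)n(CC3CC3)c2ncn1CC1CCOCC1` gives 0.272 h. Compound 2 `COc1ccc(Cn2c(-c3ccccc3)c(-c3ccccc3)c3c(=N)n(CC4CCOCC4)cnc32)cc1` gives 0.217 h; the step of a 1.3-fold lower number from compound 1 to compound 2 (0.10 log units; within the scatter) changes the substituent on the saturated chain carbon bound to the other aromatic nitrogen and is within the scatter. Compound 3 `COc1ccc(Cn2c(-c3ccccc3)c(-c3ccccc3)c3c(=N)n([C@H]4CC[C@H](O)CC4)cnc32)cc1` gives 2 h, the highest of the three numbers, standing beyond the scatter from both compound 1 and compound 2. Within the data shown here, the step of a 9.2-fold higher number from compound 2 to compound 3 (0.96 log units; beyond the scatter) is the only measured change at the ring nitrogen that now comes into play.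

Compound 4 `COc1ccc(Cn2c(-c3ccccc3)c(-c3ccccc3)c3c(=N)n(CCCO)cnc32)cc1` is not yet measured. Its change from compound 3 is 3-hydroxypropyl in place of 4-hydroxycyclohexyl on an aromatic nitrogen. Among the measured compounds shown here, this step undoes the one change that moved the number beyond the scatter, because the gain of a 9.2-fold higher number from compound 2 to compound 3 (0.96 log units; beyond the scatter) came from putting 4-hydroxycyclohexyl onto that same nitrogen, and compound 4 again carries a chain there. A downward step is therefore expected for compound 4, of roughly a 4.0-fold lower number from compound 3 to compound 4 (0.60 log units; beyond the scatter), leaving the number above compound 2 but well under compound 3. The estimate for compound 4 is 0.5 h, with a range from 0.2 h to 1.5 h.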

Compound 4, half-life: 0.332 h
Compound 4: the middle estimate sits 1.5-fold (0.18 log units) above what was measured; the measured number falls inside the stated range.
By their numbers in this assay, from the lowest: compounds 2, 1 and 4 (each within the scatter of the next); then compound 3.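

In this assay, the step of a 6.0-fold lower number from compound 3 to compound 4 (0.78 log units; beyond the scatter) shows that the high number of compound 3 does not survive replacing 4-hydroxycyclohexyl with 3-hydroxypropyl on this aromatic nitrogen, although the two groups have the same hydrogen-bond donor and acceptor counts. The step of a 1.5-fold higher number from compound 2 to compound 4 (0.18 log units; within the scatter) shows that 3-hydroxypropyl and (oxan-4-yl)methyl cannot be told apart at this position, so among these groups only 4-hydroxycyclohexyl stands beyond the scatter. No measurement shown here accounts for these differences.

The compounds shown leave open whether the gain needs the six-membered carbon ring alone or the ring together with its hydroxyl, a question that plain cyclohexyl or 4-aminocyclohexyl would address. They also leave open how a longer hydroxyalkyl chain or the other stereoisomer of 4-hydroxycyclohexyl would read at this nitrogen.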